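The source may hold more compounds than are shown below. What is called first, only, known or untested is meant among the compounds shown, and "the series" means these compounds.

Compound 1, `CCC1C(=O)N(C)c2cnc(-n3ccc4cc(C(=O)NC(C)C)ccc43)nc2N1c1ccn(C)n1`: 4350 nM
Compound 2, `CCCNC(=O)c1ccc2c(ccn2-c2ncc3c(n2)N(c2ccn(C)n2)C(CC)C(=O)N3C)c1`: 6160 nM
Compound 3, `CC[C@@H]1C(=O)N(C)c2cnc(-n3ccc4cc(C(=O)NC(C)C)ccc43)nc2N1C1CCCC1`: 292 nM

The three compounds were tested in a functional assay on HeLa cells (Homo sapiens) for antiproliferative activity, read by CCK-8 assay, with a stated time of 72 h; a higher number here means a weaker inhibitor of growth, a lower number a stronger inhibitor of growth. Compound 1 and compound 2 share one core and differ only in the group on the amide-type nitrogen, (propyl in place of isopropyl on an amide-type nitrogen). This change gave a 1.4-fold higher number from compound 1 to compound 2 (0.15 log units; within the scatter), so in this assay the two amides are not separated by the data. Compound 3 carries a second core; the difference between the two cores is not broken down here. In this assay compound 3 gives 292 nM, which stands well apart from compound 1 and from compound 2, both of whose numbers are higher by steps beyond the scatter.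

Compound 4, `CCCNC(=O)c1ccc2c(ccn2-c2ncc3c(n2)N(C2CCCC2)[C@H](CC)C(=O)N3C)c1`, is not yet measured. It stands to compound 3 as compound 2 stands to compound 1: the same change, (propyl in place of isopropyl on an amide-type nitrogen), made on the core of compound 3. Among the compounds with values here, since the one measured instance of this change, a 1.4-fold higher number from compound 1 to compound 2 (0.15 log units; within the scatter), stayed within the scatter, compound 4 is expected to sit close to compound 3, with the step of a 1.4-fold higher number from compound 3 to compound 4 (0.14 log units; within the scatter) estimated. Compound 4 is therefore expected to give about 400 nM in this assay, most likely between 180 nM and 900 nM.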

Compound 4, concentration for 50% growth inhibition: 238 nM
The estimate for compound 4 lay 1.7-fold (0.23 log units) above the measured number; the measured number falls inside the stated range.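

In this assay, the same swap of propyl in place of isopropyl on the amide-type nitrogen, now made on the core of compound 3, gave a 1.2-fold lower number from compound 3 to compound 4 (0.09 log units; within the scatter). Set beside the earlier instance on the other core, this step shows no difference that the data can separate: the same change on two cores in this assay, a 1.4-fold higher number (0.15 log units; within the scatter) from compound 1 to compound 2 and a 1.2-fold lower number (0.09 log units; within the scatter) from compound 3 to compound 4, 1.7-fold (0.24 log units) apart, within the scatter of two such steps. The series therefore shows that, on these two cores, this swap left the number within the scatter, so the outcome on one core matched the outcome on the other; it does not show that the match would hold on a further core or in another assay, and since neither step rises above the scatter, there is no clear effect of the swap whose transfer could be tested.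

The compounds shown leave open whether the amide-type nitrogen would tolerate anything other than these two chains of the same size, such as a longer butyl or hexyl chain, a 2-hydroxyethyl group or a chain ending in a dimethylamine. They also leave open whether a carboxylic acid in place of the amide would keep the numbers seen on either core.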